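This account rests on a few compounds, and the source may have more. Where it says the series, first, only, none or still open, it means among the compounds named here.

Of the compounds shown here, three sharing one core have been measured in a functional assay on HT-29 cells (Homo sapiens) for antiproliferative activity, read by sulforhodamine B assay, with a stated time of 48 h; on this read-out higher numbers stand for weaker inhibition and lower numbers for stronger inhibition. Compound 1 `CCc1ccccc1NS(=O)(=O)c1ccc(N2CCNC2=O)cc1` gives 240 nM, the second highest of the three numbers. Compound 3 `Cc1ccc(NS(=O)(=O)c2ccc(N3CCNC3=O)cc2)c(C)c1` gives 180 nM, and the step of a 1.3-fold lower number from compound 1 to compound 3 (0.12 log units; within the scatter) lies within the scatter. Compound 2 `O=C1NCCN1c1ccc(S(=O)(=O)Nc2ccc(I)cc2)cc1` gives 650 nM, and the step of a 2.7-fold higher number from compound 1 to compound 2 (0.43 log units; beyond the scatter) lies beyond it, as does the step of a 3.6-fold lower number from compound 2 to compound 3 (0.56 log units; beyond the scatter). Compound 4 `COc1cccc(NS(=O)(=O)c2ccc(N3CCNC3=O)cc2)c1` has not yet been measured in this assay; set against compound 1 the change is 3-methoxyphenyl in place of 2-ethylphenyl on a sulfonamide nitrogen. Within the data shown here, no measured step involves a methoxy group, so the only bearing comes from the two steps that exchange the group on the sulfonamide nitrogen: the step of a 1.3-fold lower number from compound 1 to compound 3 (0.12 log units; within the scatter) stayed within the scatter, whereas the step of a 2.7-fold higher number from compound 1 to compound 2 (0.43 log units; beyond the scatter) moved beyond it toward weaker inhibition. With one of two comparable replacements having raised the number, a modest rise is expected, written as a 1.7-fold higher number from compound 1 to compound 4 (0.22 log units; within the scatter), though a result within the scatter would not surprise. Compound 4 is therefore estimated at 400 nM, with a range from 150 nM to 1100 nM.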

Compound 4, half-maximal inhibitory concentration: 120 nM
Beside the measured number, compound 4's estimate is 3.3-fold (0.52 log units) above it; the whole stated range lies above it.
By their numbers in this assay, from the lowest: compounds 4, 3 and 1 (each within the scatter of the next); then compound 2.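

In this assay, among these compounds, the sulfonamide nitrogen now carries three differently substituted phenyl groups that cannot be told apart: a 2.0-fold lower number from compound 1 to compound 4 (0.30 log units; within the scatter) and a 1.5-fold lower number from compound 3 to compound 4 (0.18 log units; within the scatter) both stay within the scatter, so 3-methoxyphenyl, the first of these groups to hold an oxygen and a hydrogen-bond acceptor, fits with 2-ethylphenyl and 2,4-dimethylphenyl. Among the compounds shown here, compound 2 alone stands apart, and a 5.4-fold lower number from compound 2 to compound 4 (0.73 log units; beyond the scatter) is the largest step seen at this place, leaving 4-iodophenyl as the one group that goes against this level set. Nothing at hand explains why 4-iodophenyl differs from the other groups. The compounds shown leave open how the number responds to an amine or a carboxylic acid on the phenyl group, or to a longer chain in place of ethyl. They also leave open whether changes elsewhere in the shared core would move it.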